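Stereochemical inversion at the cyclohexyl ring carbon

This account rests on a few compounds, and the source may have more. Where it says the series, first, only, none or still open, it means among the compounds named here.

Compound 2 `O=C(O)C[C@@H]1CCCC[C@H]1n1nc(-c2c(-c3ccccc3)nn3ccccc23)ccc1=O` gives 3.6 nM in an assay on cell membranes for inhibition of adenosine receptor A1 (Rattus norvegicus) (on this read-out higher numbers stand for weaker inhibition and lower numbers for stronger inhibition), and holds the lowest of the two numbers recorded so far; its nearest neighbour is compound 1 `O=C(O)CC1=C(n2nc(-c3c(-c4ccccc4)nn4ccccc34)ccc2=O)CCC1`, which in this assay gives 11 nM. Going by the values given here, the single measured step, a 3.1-fold lower number from compound 1 to compound 2 (0.49 log units; beyond the scatter), concerns a change of the ring carrying the carboxymethyl group and nothing else.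

Compound 3 `O=C(O)C[C@H]1CCCC[C@H]1n1nc(-c2c(-c3ccccc3)nn3ccccc23)ccc1=O` differs from compound 2 only as follows: the two compounds have the same atoms and bonds and differ only in configuration as drawn: 1 of 2 stereo elements differ; a stereocentre at a saturated ring carbon is drawn S in compound 2 and R in compound 3. Among the compounds with values here, no measured step bears on a change of configuration alone; the one step recorded, from compound 1 to compound 2, alters ring size and saturation and says nothing about which diastereomer is favoured. The direction of any shift in this assay is therefore open, and a step in either direction, or none beyond the scatter, is possible.

On that basis compound 3 is expected to land near 8 nM, within a range of 2.5 nM to 30 nM, the step from compound 2 being estimated as a 2.2-fold higher number from compound 2 to compound 3 (0.35 log units; beyond the scatter).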

Compound 3, half-maximal inhibitory concentration: 34 nM
Estimate against measurement, compound 3: 4.3-fold (0.63 log units) below, and the stated range ends below it.
By their numbers in this assay, from the lowest: compound 2; then compound 1; then compound 3.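

In this assay, the configuration at a saturated ring carbon emerges as a strong determinant of the read-out: inverting this one stereocentre gives a 9.4-fold higher number from compound 2 to compound 3 (0.98 log units; beyond the scatter), a larger step than the ring change alone had shown. The exchange of 2-(carboxymethyl)cyclopent-1-en-1-yl for 2-(carboxymethyl)cyclohexyl on an aromatic nitrogen therefore has no single direction, since with the stereocentre drawn S it gives a 3.1-fold lower number from compound 1 to compound 2 (0.49 log units; beyond the scatter), whereas with it drawn R it gives a 3.1-fold higher number from compound 1 to compound 3 (0.49 log units; beyond the scatter). The shift between the two cyclohexyl compounds can be assigned to this stereocentre alone because no other structural change accompanies it: the fact that compounds 2 and 3 differ only in the configuration as drawn.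

Still open, on these data alone, is whether the preference for the S drawing holds when the second stereocentre is inverted, or when the cyclohexyl ring gives way to a saturated cyclopentyl ring. Equally open, as far as these compounds go, is whether the gap between the two configurations persists when the carboxylic acid is replaced by a primary amide or the carboxymethyl group by a longer carboxypropyl chain.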